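Hexyl for phenylethyl on an acylguanidine partial agonist

The compounds below may be only part of what the source reports. "The series", "measured", "known", "first", "only" and "open" are said of these compounds alone.

Measured compounds:
compound 1, `Cc1nc(N)sc1CCCN/C(N)=N/C(=O)N[C@H](C)c1ccccc1`: 0.34
compound 2, `CCCNC(=O)/N=C(\N)Nc1cccc(-c2csc(N)n2)c1`: "not determined" (no result reported)

Among the compounds with values here, compound 1 is the only compound of the pair with a number in a functional assay on HEK293T cells for agonist activity at histamine H2 receptor (Homo sapiens), read by beta-arrestin recruitment; on this read-out higher numbers stand for larger maximal responses and lower numbers for smaller maximal responses. In this assay compound 1 gives 0.34, a partial response well short of the reference agonist. Within the data shown here, compound 2 is the other measured entry in this assay, for which compound 2 is recorded as "not determined" (no result reported), so it offers no second point for comparison and no step between measured compounds can be drawn.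

Compound 3, `CCCCCCNC(=O)/N=C(\N)NCCCc1sc(N)nc1C`, is the unmeasured compound. It differs from compound 1 at a single place: hexyl in place of 1-phenylethyl on an amide-type nitrogen. Among the measured compounds shown here, with no measured step to lean on, the expectation rests on compound 1 alone, whose 0.34 sits in the lower part of the scale and leaves room in either direction. The step a number 0.11 higher from compound 1 to compound 3 (beyond the scatter) is expected to be a modest rise, roughly at the edge of the usual scatter, with a wide range allowed on both sides. For compound 3 the estimate in this assay is 0.45, expected to fall between 0.2 and 0.75.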

Compound 3, intrinsic activity: the largest response reached, as a fraction of the reference agonist's: 0.28
For compound 3 the middle estimate is 0.17 above the measured one; measured number inside the range.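

In this assay, within the data shown here, the exchange of 1-phenylethyl for hexyl on the amide-type nitrogen gives a number 0.060 lower from compound 1 to compound 3 (within the scatter), the first reading of any change at this position. For this pair, then, the maximal response does not depend on the six-membered aromatic ring or on the defined stereocentre of the group that leaves, since an open chain of hexyl with no ring and no stereocentre gives a result that cannot be told apart from that of the 1-phenylethyl group, and the partial character of the response stays in place with either substituent. No available information accounts for why these two different groups read alike, and this single pair gives no ground for a cause.

What the compounds shown leave open is whether this tolerance extends to other groups on the same nitrogen, such as a longer chain like octyl, a shorter one like butyl, or a ring like cyclohexyl. They also leave open whether the other stereoisomer of 1-phenylethyl, or a benzyl group, would give a maximal response beyond the scatter of the two values in hand.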